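Cytotoxicity notes on three aryl analogues and a fourth

The compounds below may be only part of what the source reports. "The series", "measured", "known", "first", "only" and "open" are said of these compounds alone.

Compound 1 `COc1ccc(-c2nc3c(c(C)nn3-c3ccccc3)c(-c3ccccc3O)c2C#N)cc1`: in an ADME assay on BJ cells (Homo sapiens) for cytotoxicity, with a stated time of 72 h (on this read-out higher numbers stand for an effect only at larger amounts of compound and lower numbers for an effect already at smaller amounts), compound 1 gives > 23000 nM, which is a limit of the assay.
Compound 2 `Cc1cccc(-c2nc3c(c(C)nn3-c3ccccc3)c(-c3ccccc3O)c2C#N)c1`: in this assay compound 2 gives > 20000 nM, also a limit.
Compound 3 `Cc1nn(-c2ccccc2)c2nc(-c3ccc4ccccc4c3)c(C#N)c(-c3ccccc3O)c12`: in this assay compound 3 gives > 20000 nM, again a limit.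

Compound 3 therefore stands only at a limit, and the two other values shown are limits as well, so no order among the three can be read. The steps a step that the two limits leave unreadable from compound 1 to compound 3 and a step that the two limits leave unreadable from compound 2 to compound 3 are both unreadable, as is a step that the two limits leave unreadable from compound 1 to compound 2; two of the values sit at the limit of > 20000 nM in this assay, at which 2 of the 3 values shown sit, and one at the limit of > 23000 nM in this assay, at which 1 of the 3 values shown sits.

Compound 4 `CCc1cccc(-c2nc3c(c(C)nn3-c3ccccc3)c(-c3ccccc3O)c2C#N)c1` differs from compound 3 as follows: 3-ethylphenyl in place of naphthalen-2-yl on an aromatic carbon. Within the data shown here, the measured steps that bear on this change, swapping one aryl group for another at the same carbon, all proved unreadable, so no step in this assay beyond the scatter is expected; another limit is the most probable outcome. The step that the limit leaves unreadable from compound 3 to compound 4 is expected to be essentially nil. Compound 4 is estimated at 25000 nM, within 10000 nM to 60000 nM.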

Compound 4, half-maximal effective concentration: > 20000 nM
Compound 4: only a limit was reported (the forecaster's own chance of this, stated with the estimate: 85%); the middle value does not contradict the limit.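

In this assay compound 4 gives > 20000 nM, which is a limit. Its steps to compound 1, compound 2 and compound 3 all join limits and cannot be read. The compounds shown leave open where any effect on these cells would begin and whether changing the aryl group shifts it.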